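A few compounds are considered here, and "the series" means these few. Any claim that something is new, unique, unknown or untested is made for them only; others in the source may bear on it.

Three analogues on a shared core have numbers in a functional assay on A549 cells (Homo sapiens) for inhibition, read by sulforhodamine B assay, with a stated time of 48 h; a lower number here means a stronger inhibitor of growth, a higher number a weaker inhibitor of growth. Compound 1 `COc1ccc2c(c1)NC(=O)CN2c1nc(NCCCO)nc2ccccc12` gives 5.18 nM. Compound 2 `COc1ccc2c(c1)NC(=O)CN2c1nc(Nc2ccc(C#N)cc2)nc2ccccc12` gives 6.17 nM. Compound 3 `COc1ccc2c(c1)NC(=O)CN2c1nc(NCc2ccncc2)nc2ccccc12` gives 6.62 nM. Compound 2 stands second highest of the three numbers, with compound 3 nearest and compound 1 furthest; the steps among the three, a 1.2-fold higher number from compound 1 to compound 2 (0.08 log units; within the scatter), a 1.3-fold higher number from compound 1 to compound 3 (0.11 log units; within the scatter) and a 1.1-fold higher number from compound 2 to compound 3 (0.03 log units; within the scatter), all lie within the scatter, so no order can be read among them.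

The next compound, compound 4 `COc1ccc2c(c1)NC(=O)CN2c1nc(COC(C)=O)nc2ccccc12`, has not yet been measured in this assay. It differs from compound 2 in one place:
acetoxymethyl in place of (4-cyanophenyl)amino on an aromatic carbon

For the measured compounds named here, none of the measured steps removes the nitrogen that carries the 3-hydroxypropyl, 4-cyanophenyl or (pyridin-4-yl)methyl group; those steps only show that exchanging what sits on that nitrogen leaves this assay flat. Going by the values given here, on that basis the expected step for compound 4 is a 1.3-fold higher number from compound 2 to compound 4 (0.11 log units; within the scatter), essentially none beyond the scatter, though with a wider range than usual since no measured step covers this kind of change. The number expected for compound 4 is 8 nM, within 3 nM to 25 nM.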

Compound 4, concentration for 50% growth inhibition: 5.52 nM
Compound 4: middle estimate off by 1.4-fold (0.16 log units), on the high side, within the range that was stated.
By their numbers in this assay, from the lowest: compounds 1, 4, 2 and 3 (each within the scatter of the next).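

In this assay this aromatic carbon, between two ring nitrogen atoms, now carries a group without the linking nitrogen, and the exchange gives a 1.1-fold lower number from compound 2 to compound 4 (0.05 log units; within the scatter) and a 1.2-fold lower number from compound 3 to compound 4 (0.08 log units; within the scatter) and also a 1.1-fold higher number from compound 1 to compound 4 (0.03 log units; within the scatter) in the three comparisons, all within the scatter. Across compounds 1 to 4, then, an attached nitrogen at this place is not required for a number in this range, and from compound 2 to compound 4 the six-membered aromatic ring and the hydrogen-bond donor also leave without a step beyond the scatter. Nothing at hand accounts for this flatness.

On these data alone, whether any group at this carbon matters stays open, and a bare hydrogen, a carboxylic acid or a primary amine there would probe it. As far as these compounds go, what the methoxy group and the amide hydrogen contribute also stays open, as all four compounds carry both.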